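This account rests on a few compounds, and the source may have more. Where it says the series, first, only, none or still open, it means among the compounds named here.

Compound 1 `CC(C)n1cc(-c2ccnc3[nH]c(C4CCN(CC(=O)N(C)C)CC4)cc23)ccc1=O`: 2.3 uL/min
Compound 2 `CCn1cc(-c2ccnc3[nH]c(C4CCN(CC(=O)N(C)C)CC4)cc23)ccc1=O`: < 1 uL/min

Of the compounds shown here, two have so far been measured in an ADME assay on cells (Hepatocyte, Rattus norvegicus) for metabolic stability; a lower number here means slower removal, a higher number faster removal of the compound. Compound 1 gives 2.3 uL/min. Compound 2 gives only a limit, < 1 uL/min, so its exact number is not known. The mark the limit of < 1 uL/min in this assay, at which 1 of the 2 values shown sits, shows where compound 2 sits: of the two values shown it is the lower, and it is the only one that rests on a limit rather than a number. For the measured compounds named here, the single measured step, an at least 2.3-fold lower number from compound 1 to compound 2 (0.36 log units; beyond the scatter), shows that hydrogen in place of methyl on a saturated chain carbon bound to an aromatic nitrogen lowered the number at least modestly.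

Compound 3 `CN(C)C(=O)CN1CCC(c2cc3c(-c4ccc(=O)n(CC5CCOCC5)c4)ccnc3[nH]2)CC1` differs from compound 2 at that same saturated chain carbon: oxan-4-yl in place of methyl on a saturated chain carbon bound to an aromatic nitrogen. The measured step removed one carbon there; this change instead brings in a six-membered ring. Taking the measured step as a pointer, the number is expected to rise rather than fall, by an at least 2.5-fold higher number from compound 2 to compound 3 (0.39 log units; beyond the scatter), though from a starting point known only as a limit. Compound 3 is therefore expected to give about 2.5 uL/min, within a range from 0.6 uL/min to 10 uL/min.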

Compound 3, intrinsic clearance in a liver preparation (reported as CLH), per the amount of preparation that the assay uses: 1.8 uL/min
Compound 3: middle estimate off by 1.4-fold (0.14 log units), on the high side; the range from low to high includes it.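

Until now the aromatic nitrogen had carried only small open chains, and compound 3 adds a ring there. In this assay, exchanging isopropyl for (oxan-4-yl)methyl gives a 1.3-fold lower number from compound 1 to compound 3 (0.11 log units; within the scatter), so this larger ring-bearing group cannot be told apart from isopropyl in this measurement. Exchanging methyl for oxan-4-yl on the saturated chain carbon bound to the aromatic nitrogen gives an at least 1.8-fold higher number from compound 2 to compound 3 (0.25 log units; that floor lies within the scatter), so the data do not establish a real difference, and the true size of the step stays unknown since compound 2 rests on a limit: the limit of < 1 uL/min in this assay, at which 1 of the 3 values shown sits.

What the compounds shown leave open is whether the oxygen in the ring matters, which a cyclohexylmethyl group at the same place would help to show. They also leave open how much the link between the ring and the aromatic nitrogen matters, which a longer chain leading to the oxan-4-yl ring, or an oxan-4-yl group set directly on that nitrogen, would help to settle.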